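Ether for amine on the shared core of compound 2

This account rests on a few compounds, and the source may have more. Where it says the series, first, only, none or still open, it means among the compounds named here.

Measured compounds:
compound 1 `COCCCNc1nc(C)nc2c1nnn2-c1ccc(C(C)C)cc1Br` gives 291 nM
compound 2 `CCN(CC)c1nc(C)nc2c1ncn2-c1ccc(C(C)C)cc1Br` gives 12.4 nM
compound 3 `CCCCN(CC)c1nc(C)nc2c1nc(C)n2-c1c(Cl)cc(OC)cc1OC` gives 3.5 nM

All three values come from an in vitro assay on 293-EBNA cells for binding affinity to corticotropin-releasing factor receptor 1 (Homo sapiens); on this read-out lower numbers stand for stronger inhibition and higher numbers for weaker inhibition. Among them compound 2 stands second highest: compound 3 sits lower, and that gap lies beyond the scatter, while compound 1 sits far higher, also beyond the scatter. Compound 1 and compound 3 are not single-point neighbours of compound 2, so their numbers say only where compound 2 lies on the scale, not what any one change is worth.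

Compound 4 `CCC(CC)Oc1nc(C)nc2c1ncn2-c1ccc(C(C)C)cc1Br` has not yet been measured in this assay. It differs from compound 2 in one place: (pentan-3-yl)oxy in place of diethylamino on an aromatic carbon. The diethylamino that leaves and the (pentan-3-yl)oxy that enters are counted as groups of similar size, each carrying one hydrogen-bond acceptor and no donor, so the expectation rests on the value of compound 2 at 12.4 nM rather than on any measured step.

Compound 4 is therefore expected to land near compound 2, at an estimated 20 nM, within a range of 5 nM to 80 nM. The expected step, a 1.6-fold higher number from compound 2 to compound 4 (0.21 log units; within the scatter), points toward a slightly higher number, small enough that it may fall within the scatter.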

Compound 4, inhibition constant: 3.5 nM
Compound 4: the middle estimate sits 5.7-fold (0.76 log units) above what was measured; measured number outside the range, below it.
By their numbers in this assay, from the lowest: compounds 3 and 4 (each within the scatter of the next); then compound 2; then compound 1.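

In this assay, for the compounds shown here, the change from diethylamino to (pentan-3-yl)oxy gives a 3.5-fold lower number from compound 2 to compound 4 (0.55 log units; beyond the scatter) and is the first step in this set that can be read for a single change. It shows that, on this pair, the amine nitrogen on this aromatic carbon next to the ring nitrogen can give way to an ether oxygen without loss of binding, and that the pair with the oxygen has the lower number, something the values of compound 1 and compound 3 could not show because neither is a single-point neighbour of compound 2. The two groups carry the same counts of hydrogen-bond donors and acceptors, so those counts do not separate them, and nothing measured here bears on why the number falls.

This single pair cannot separate the exchange of nitrogen for oxygen from the change in the carbon chain, which the pentan-3-ylamino group, an amine with the same chain as compound 4, would help to resolve. It also leaves open whether a smaller ether such as methoxy would behave alike, or whether the step would carry over to the core of compound 3.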